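Compound 4: One Trifluoromethyl Fewer Than Compound 3

The source may report more compounds than this note shows. Statements on the series, on what has been measured and on what is new or still open speak of the compounds shown alone.

Of the compounds shown here, three with a shared core have been tested in a functional assay on MDA-MB-435 cells (Homo sapiens) for inhibition, read by sulforhodamine B assay, with a stated time of 48 h, tested at 100 uM; a higher number here means a weaker effect of the compound at the concentration tested, a lower number a stronger effect. Compound 1 `O=C(Nc1cccc(-n2cc(-c3ccncc3)c(-c3cc(O)cc(Cl)c3)n2)c1)Nc1ccc(Cl)c(C(F)(F)F)c1` gives -93% in this assay. Compound 2 `O=C(Nc1cccc(-n2cc(-c3ccncc3)c(-c3cc(O)cc(Cl)c3)n2)c1)Nc1ccc(Cl)c(Cl)c1` gives -45%. Compound 3 `COc1cc(Cl)cc(-c2nn(-c3cccc(NC(=O)Nc4cc(C(F)(F)F)cc(C(F)(F)F)c4)c3)cc2-c2ccncc2)c1` gives -81%, which is the second highest of the three numbers: its nearest neighbour is compound 1, whose number lies lower beyond the scatter, and its furthest is compound 2, whose number lies higher beyond the scatter.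

Compound 4 `COc1cc(Cl)cc(-c2nn(-c3cccc(NC(=O)Nc4cccc(C(F)(F)F)c4)c3)cc2-c2ccncc2)c1` differs from compound 3 by hydrogen in place of trifluoromethyl on an aromatic carbon. Among the compounds with values here, the only measured step that bears on this is a number 48 percentage points higher from compound 1 to compound 2 (beyond the scatter), in which a trifluoromethyl was also lost, although chloro entered there rather than hydrogen and no second trifluoromethyl remained. Compound 4 keeps one trifluoromethyl, so a rise in this assay is expected, probably smaller than that step. Compound 4 is therefore estimated to give -45%, with a range of -80% to -5%. This estimate corresponds to an expected a number 36 percentage points higher from compound 3 to compound 4 (beyond the scatter).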

Compound 4, a percentage reported as activity, at one concentration (the size of the read-out at that concentration, not a potency): -74%
Beside the measured number, compound 4's estimate is 29 percentage points above it, within the range that was stated.
By their numbers in this assay, from the lowest: compound 1; then compounds 3 and 4 (each within the scatter of the next); then compound 2.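

In this assay, hydrogen in place of trifluoromethyl on this aromatic carbon, meta to a trifluoromethyl group, gives a number 7 percentage points higher from compound 3 to compound 4 (within the scatter), so this position tolerates the loss of one of the two trifluoromethyl groups with no change beyond the scatter. Losing a trifluoromethyl therefore does not by itself go with a large step in these compounds, in contrast to a number 48 percentage points higher from compound 1 to compound 2 (beyond the scatter), where chloro replaces trifluoromethyl on a different background. No measurement at hand explains this contrast.

Whether the remaining trifluoromethyl of compound 4 is needed for the read-out stays open, as the compounds shown offer no step that removes it. Also open, on these data alone, is how an amine, a carboxylic acid or a longer chain on this aromatic carbon would read in this assay.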